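This account rests on a few compounds, and the source may have more. Where it says the series, first, only, none or still open, it means among the compounds named here.

Measured so far in a functional assay on HCT-116 cells (Homo sapiens) for cytotoxicity, read by MTT assay, with a stated time of 72 h; on this read-out higher numbers stand for weaker inhibition and lower numbers for stronger inhibition:
- compound 1 `CC(=O)c1ccc(/N=C2\C=C(OCc3cn(S(=O)(=O)c4ccc(C)cc4)nn3)C(=O)c3ccccc32)cc1`: 6270 nM
- compound 2 `Cc1ccc(S(=O)(=O)n2cc(COC3=C/C(=N\c4ccc(Br)cc4)c4ccccc4C3=O)nn2)cc1`: 9250 nM

With only these two numbers to compare, compound 2 at 9250 nM lies within the usual scatter of compound 1, so the two cannot be ranked. Compound 3 `Cc1ccc(/N=C2\C=C(OCc3cn(S(=O)(=O)c4ccc(C)cc4)nn3)C(=O)c3ccccc32)cc1` has not been measured yet. It differs from compound 2 by a single swap, methyl in place of bromo on an aromatic carbon. Going by the values given here, one measured step bears on this, bromo in place of acetyl on an aromatic carbon, which gave a 1.5-fold higher number from compound 1 to compound 2 (0.17 log units; within the scatter). That is thin evidence, since a methyl group has not been tested in this series. No step beyond the scatter is therefore expected in this assay, and the estimated move is a 1.2-fold lower number from compound 2 to compound 3 (0.06 log units; within the scatter). For compound 3 the expected value is 8000 nM, with an estimated range of 3500 nM to 18000 nM.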

Compound 3, half-maximal inhibitory concentration: 3610 nM
Estimate against measurement, compound 3: 2.2-fold (0.35 log units) above, within the range that was stated.
By their numbers in this assay, from the lowest: compounds 3, 1 and 2 (each within the scatter of the next, the first and the last beyond it).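

In this assay the change from 4-bromophenyl to 4-methylphenyl gives a 2.6-fold lower number from compound 2 to compound 3 (0.41 log units; beyond the scatter) and is the only step shown that lies beyond the scatter, so swapping a single heavy atom at this place on the ring can shift the read-out measurably. Methyl against acetyl gives a 1.7-fold lower number from compound 1 to compound 3 (0.24 log units; within the scatter) and stays within the scatter, so those two groups cannot be ranked, and compound 1 cannot be separated from either of its neighbours. Nothing available here accounts for the gap between methyl and bromo.

As far as these compounds go, whether a longer chain such as ethyl, or an amine or a carboxylic acid, would give a lower or a higher number at this place remains open. So does whether the methyl-over-bromo step would hold on a different core.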